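The source may report more compounds than this note shows. Statements on the series, on what has been measured and on what is new or still open speak of the compounds shown alone.

Compound 1 `Cn1cc(NC(=O)c2ccncc2Nc2cc(-c3ccc4ccn(C)c4c3)c3nccnc3c2)cn1` gives 33 nM in an assay for inhibition of 6-phosphofructo-2-kinase/fructose-2,6-bisphosphatase 3 (Homo sapiens), read by ADP-Glo, with a stated time of 2 h; a higher number here means a weaker inhibitor, a lower number a stronger inhibitor. Compound 2 `Cn1ccc2ccc(-c3cc(Nc4cnccc4C(=O)NCC4COCCN4)cc4nccnc34)cc21` gives 33 nM; the step of no change at the digits printed from compound 1 to compound 2 (within the scatter) shows that swapping the group on the amide-type nitrogen left the read-out where it was. Compound 2 therefore stands level with compound 1 at the digits shown, the two values lying within the scatter of each other.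

Compound 3 `CN1CC(NC(=O)c2ccncc2Nc2cc(-c3ccc4ccn(C)c4c3)c3nccnc3c2)C1` carries the next change at the same position: 1-methylazetidin-3-yl in place of (morpholin-3-yl)methyl on an amide-type nitrogen. Going by the values given here, the only measured step that bears on this position is the flat one from the pyrazolyl to the morpholinylmethyl group, so the amide substituent has so far not moved the number. On that basis the expected step is a 1.2-fold higher number from compound 2 to compound 3 (0.08 log units; within the scatter), that is, no shift beyond the scatter, with the direction left open.

Compound 3 is accordingly estimated at 40 nM, with a range of 15 nM to 110 nM.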

Compound 3, half-maximal inhibitory concentration: 30 nM
Compound 3: the middle estimate sits 1.3-fold (0.12 log units) above what was measured; the measured number falls inside the stated range.
By their numbers in this assay, from the lowest: compounds 3, 1 and 2 (each within the scatter of the next).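

In this assay, a third group on the amide-type nitrogen again produces no shift beyond the scatter: a 1.1-fold lower number from compound 2 to compound 3 (0.04 log units; within the scatter), and a 1.1-fold lower number from compound 1 to compound 3 (0.04 log units; within the scatter). The position therefore reads the same with 1-methylazetidin-3-yl, a four-membered non-aromatic ring with 5 heavy atoms and 0 hydrogen-bond donors, as with (morpholin-3-yl)methyl, a six-membered non-aromatic ring with 7 heavy atoms and 1 hydrogen-bond donor. No measurement at hand explains this flat read-out.

Still open, on these data alone, is whether the number would hold with an acyclic group on this nitrogen, such as a longer alkyl chain ending in a primary amine or a carboxylic acid. The compounds shown also differ only at this position, so they give no reading on changes to the shared core.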